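Three Compounds at the Limit, and a Fourth to Come

The source may report more compounds than this note shows. Statements on the series, on what has been measured and on what is new or still open speak of the compounds shown alone.

Of the compounds shown here, three have been tested in an ADME assay on PBMC cells (Homo sapiens) for cytotoxicity, with a stated time of 72 h; a higher number here means a weaker inhibitor, a lower number a stronger inhibitor. Compound 1 `Cn1c(Sc2c(F)cc(C(=O)NO)cc2F)nnc1-c1cccnn1` gives > 1000 nM, which is a limit of the assay rather than a measured number. Compound 2 `O=C(NO)c1cc(F)c(Cn2nnc(-c3ccccn3)n2)c(F)c1` likewise gives > 1000 nM, again a limit. Compound 3 `O=C(NO)c1cc(F)c(Cc2nnc(-c3ccncc3)s2)c(F)c1` gives > 1000 nM, also a limit. All three therefore stand at the same point: the limit of > 1000 nM in this assay, at which 3 of the 3 values shown sit. Compound 2 thus sits where every other measured compound sits, with no number of its own, and no measured difference from compound 1 or compound 3 can be read.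

The next compound, compound 4 `Nc1ccc(-c2nnn(Cc3c(F)cc(C(=O)NO)cc3F)n2)cc1`, differs from compound 2 in a single respect: 4-aminophenyl in place of pyridin-2-yl on an aromatic carbon.

For the measured compounds named here, no step between measured compounds is available, so nothing shows how far a change of this kind moves the read-out in this assay. Going by the values given here, what the three measured values do show is that every member of the series so far has stayed at the limit. The expectation for compound 4 is therefore that it too will stay there, and the expected step is a step that the limit leaves unreadable from compound 2 to compound 4, none beyond the scatter. The estimate for compound 4 is 3000 nM, within a range from 1000 nM to 10000 nM, most likely reported once more only as a limit.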

Compound 4, half-maximal inhibitory concentration: > 1000 nM
Compound 4: no number, only a limit (the forecaster's own chance of this, stated with the estimate: 80%); the middle value does not contradict the limit.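

In this assay compound 4 gives > 1000 nM, which is a limit of the assay and not a number. Compound 2 also gives only a limit, so no step can be read from compound 2 to compound 4. The series stands together: the limit of > 1000 nM in this assay, at which 4 of the 4 values shown sit. The compounds shown leave open what value any of them would reach and whether any structural change moves the read-out.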